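Bromo for methoxy on the shared core: intrinsic activity

This account rests on a few compounds, and the source may have more. Where it says the series, first, only, none or still open, it means among the compounds named here.

Of the compounds shown here, three have been measured in an assay on ileum (strain Hartley) with 5-hydroxytryptamine receptor 3A (Cavia porcellus) as the target; on this read-out higher numbers stand for larger maximal responses and lower numbers for smaller maximal responses. Compound 3, `COc1ccc2oc(N3CCN(C)CC3)nc2c1`, gives 0.78, the highest of the three numbers. Compound 1, `Cc1cccc2nc(N3CCN(C)CC3)oc12`, gives 0.58, lower by a margin beyond the scatter, and compound 2, `CCc1cc(C)cc2nc(N3CCN(C)CC3)oc12`, gives 0.26, further below and also beyond the scatter. No pair among these three differs in a single place, so no single step can be read from them; the three values only show that compound 3 reaches the largest response so far.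

Compound 4, `CN1CCN(c2nc3cc(Br)ccc3o2)CC1`, has not yet been measured. It differs from compound 3 in one place: bromo in place of methoxy on an aromatic carbon. The rest of the molecule is the same in both.

Going by the values given here, no measured step of this kind exists, so the expectation rests only on the value of compound 3 and the spread of the other two. A downward step is expected, with the change from compound 3 to compound 4 estimated at a number 0.23 lower from compound 3 to compound 4 (beyond the scatter), because compound 3 sits at 0.78 while the two other measured compounds lie well below it. Compound 4 is expected to give about 0.55 in this assay, within a range from 0.3 to 0.8.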

Compound 4, intrinsic activity: the largest response reached, as a fraction of the reference agonist's: 0.48
For compound 4 the middle estimate is 0.070 above the measured one; low and high end bracket the measured number.
By their numbers in this assay, from the lowest: compound 2; then compounds 4 and 1 (each within the scatter of the next); then compound 3.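

Going by these compounds alone, on the substituted aromatic carbon of the shared core, this assay now gives a first reading of a single change: bromo in place of methoxy moves the number a number 0.30 lower from compound 3 to compound 4 (beyond the scatter), so the group at this position matters to the maximal response, which the earlier compounds could not show. The response is lowered but not lost, with compound 4 still at 0.48 in the same read-out. No measurement at hand speaks to why the number moves with this exchange.

One step cannot separate what leaving methoxy contributes from what entering bromo contributes, and a chloro group, a hydroxy group or an amine on the same carbon would show whether methoxy is unusual here or bromo is. From the compounds shown here alone, it also remains open whether the same exchange gives a step of similar size with the other substitution patterns seen in compound 1 and compound 2, as a single pair at one position says nothing about the series as a whole.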